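Benzoyl to benzyloxycarbonyl: compound 3 to compound 4

The source may hold more compounds than are shown below. What is called first, only, known or untested is meant among the compounds shown, and "the series" means these compounds.

Of the compounds shown here, three have been read so far in a functional assay on Jurkat cells (Homo sapiens) for cytotoxicity, with a stated time of 72 h; on this read-out higher numbers stand for an effect only at larger amounts of compound and lower numbers for an effect already at smaller amounts. Compound 1 (`C=C[C@@](C)(/C=C/c1ccc(OCc2ccccc2)cc1)CCC=C(C)C`) gives > 49000 nM as a limit of the assay, not a number. Compound 2 (`C=C[C@@](C)(/C=C/c1ccc(O)cc1)CCC1OC1(C)C`) gives > 49000 nM as a limit as well. Compound 3 (`C=C[C@@](C)(/C=C/c1ccc(O)c(/C=C/C(=O)c2ccccc2)c1)CCC=C(C)C`) also gives > 49000 nM as a limit, and that is all that is known of its standing. The whole set is summed up as the limit of > 49000 nM in this assay, at which 3 of the 3 values shown sit, and no pair among these compounds differs in one place, so no measured step is available.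

Compound 4 (`C=C[C@@](C)(/C=C/c1ccc(O)c(/C=C/C(=O)OCc2ccccc2)c1)CCC=C(C)C`) carries benzyloxy in place of phenyl on a carbonyl carbon, which reads one bond further out as benzoyl to benzyloxycarbonyl. The counted difference is benzyloxy in place of phenyl on a carbonyl carbon and nothing measured yet shows what this exchange does.

With compound 3 at > 49000 nM as a limit, the reference point for the expectation is itself not a number. No change beyond the scatter is expected in this assay and the expected size is a number no higher from compound 3 to compound 4 (the limit leaves the size open) with any movement more likely toward lower numbers. In this assay the estimate for compound 4 is 49000 nM with an expected range from 20000 nM to 60000 nM and a reading that is again only a limit is the likeliest outcome.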

Compound 4, half-maximal effective concentration: > 49000 nM
Compound 4 gave a limit, no number; the forecaster's own chance of this, stated with the estimate: 70%; the middle value lies on the limit itself.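

In this assay compound 4 gives > 49000 nM, a limit of the assay and not a number. Compound 3 also stands only as a limit, so no step can be read between compound 3 and compound 4. The series remains at a single reading: the limit of > 49000 nM in this assay, at which 4 of the 4 values shown sit. The compounds shown leave open which change to the shared core, if any, would give a measurable number in this assay.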